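The source may hold more compounds than are shown below. What is called first, only, known or untested is meant among the compounds shown, and "the series" means these compounds.

Measured so far in a functional assay on PC-3 cells (Homo sapiens) for antiproliferative activity, with a stated time of 72 h; a lower number here means a stronger inhibitor, a higher number a weaker inhibitor:

Compound 1 `COc1cc(OC)c(C(=O)/C=C/c2ccccc2Cl)c(O)c1CN1CCCCC1` gives 1700 nM
Compound 2 `COc1cc(OC)c(C(=O)/C=C/c2ccccc2Cl)c(O)c1CN(C)CC(=O)O` gives 12500 nM
Compound 3 `CCN(CC)Cc1c(OC)cc(OC)c(C(=O)/C=C/c2ccccc2Cl)c1O` gives 4200 nM

Of these three, compound 2 has the highest number at 12500 nM and so is the weakest inhibitor here. Compound 4 `COc1cc(OC)c(C(=O)/C=C/c2ccccc2Cl)c(O)c1CN(C)C` departs from compound 2 by one change hydrogen in place of carboxy on a saturated chain carbon bound to an amine nitrogen with hydrogen in place of carboxy on a saturated chain carbon bound to an amine nitrogen. This turns (carboxymethyl)(methyl)amino into dimethylamino.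

Going by the values given here, two measured steps bear on this, since each links the carboxy-bearing amine of compound 2 to an amine without carboxy. Moving to diethylamino gave a 3.0-fold lower number from compound 2 to compound 3 (0.47 log units; beyond the scatter) and the opposite comparison, starting from piperidin-1-yl, gave a 7.4-fold higher number from compound 1 to compound 2 (0.87 log units; beyond the scatter). Both are modest but beyond the scatter. Dimethylamino also lacks the carboxy, so a modest drop in the number in this assay is expected, and diethylamino is taken as the closer match. The estimated change is a 3.1-fold lower number from compound 2 to compound 4 (0.49 log units; beyond the scatter). Compound 4 is expected at 4000 nM with an estimated range of 1500 nM to 10000 nM.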

Compound 4, half-maximal inhibitory concentration: 400 nM
Compound 4: middle estimate off by 10-fold (1.00 log units), on the high side; measured number outside the range, below it.
By their numbers in this assay, from the lowest: compound 4; then compound 1; then compound 3; then compound 2.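

In this assay, swapping (carboxymethyl)(methyl)amino for dimethylamino produces a large step, a 31-fold lower number from compound 2 to compound 4 (1.49 log units; beyond the scatter), and makes compound 4 the strongest inhibitor of the four. Losing the carboxy cannot be the whole story, as compound 4 also outperforms the other two amines without carboxy: an 11-fold lower number from compound 3 to compound 4 (1.02 log units; beyond the scatter) and a 4.3-fold lower number from compound 1 to compound 4 (0.63 log units; beyond the scatter). The groups on this amine nitrogen therefore matter even when no carboxy is present, and diethylamino, not piperidin-1-yl, stands furthest from dimethylamino.

No measurement here explains why these amines differ. On these data alone, it remains open how the number would respond to a morpholin-4-yl group, a methylamino group or a methyl ester in place of the carboxylic acid of compound 2.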